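The compounds below may be only part of what the source reports. "The series", "measured", "known", "first", "only" and "open" are said of these compounds alone.

Compound 1 `CC(O)c1cn(Cc2cc(=O)oc3cc(O)ccc23)nn1` — > 100000 nM
Compound 2 `O=c1cc(Cn2cc(CCCO)nn2)c2ccc(O)cc2o1` — > 100000 nM
Compound 3 `CCCCCc1ccc(-c2cn(Cc3cc(=O)oc4cc(O)ccc34)nn2)cc1` — 27300 nM

In a functional assay on HepG2 cells (Homo sapiens) for inhibition, read by MTT assay, with a stated time of 72 h (a higher number here means a weaker inhibitor, a lower number a stronger inhibitor), compound 2 reaches only a limit, > 100000 nM. Compound 1 likewise reaches only a limit, > 100000 nM. Compound 3 gives a number, 27300 nM. The step that the two limits leave unreadable from compound 1 to compound 2 cannot be read because both of its ends sit at the limit of > 100000 nM in this assay, at which 2 of the 3 values shown sit. Compound 4 `O=c1cc(Cn2cc(CSC(=S)N3CCNCC3)nn2)c2ccc(O)cc2o1` differs from compound 2 by a group of 9 heavy atoms (5 carbon, 2 nitrogen, 2 sulfur; one six-membered non-aromatic ring with 2 hetero atoms) in place of a group of 3 heavy atoms (2 carbon, 1 oxygen; no ring), on a saturated chain carbon bound to an aromatic carbon. Among the measured compounds shown here, no measured step bears on this change, and the one step between measured compounds is itself unreadable, so nothing here points in a direction. The step of an at least 1.2-fold lower number from compound 2 to compound 4 (0.09 log units; that floor lies within the scatter) is therefore expected to be no larger than the scatter, with a fair chance that only a limit is seen again. Compound 4 is expected to give 80000 nM in this assay, within a range from 20000 nM to 300000 nM.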

Compound 4, half-maximal inhibitory concentration: > 100000 nM
Compound 4 ended at the assay's limit (the forecaster's own chance of this, stated with the estimate: 55%); at least 1.2-fold (0.09 log units) between middle value and limit.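

The step from compound 2 to compound 4 cannot be read, since both compounds end at a limit, not a number: the limit of > 100000 nM in this assay, at which 3 of the 4 values shown sit.

Going by these compounds, whether the ring-bearing group in compound 4 changes inhibition at all, in either direction, stays open.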